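A Nitro Group Enters Where a Methoxy Group Left

The source may report more compounds than this note shows. Statements on the series, on what has been measured and on what is new or still open speak of the compounds shown alone.

Among the measured compounds shown here, compound 2 `COc1ccccc1NC(=O)c1ccc(/N=N\c2c[nH]c3ccccc23)cc1` holds the lower of the two numbers measured so far in a functional assay on HCT-116 cells (Homo sapiens) for inhibition, read by MTT assay, with a stated time of 72 h; a lower number here means a stronger inhibitor, a higher number a weaker inhibitor: compound 2 gives 122000 nM, while compound 1 `Cc1cccc(NC(=O)c2ccc(/N=N\c3c[nH]c4ccccc34)cc2)c1C` gives 272000 nM. For the measured compounds named here, the only step measured, a 2.2-fold lower number from compound 1 to compound 2 (0.35 log units; beyond the scatter), swaps the group carried on the amide-type nitrogen, and it is the sole guide for the next change at that same place. Compound 3 `O=C(Nc1ccc([N+](=O)[O-])cc1)c1ccc(/N=N\c2c[nH]c3ccccc23)cc1` differs from compound 2 by 4-nitrophenyl in place of 2-methoxyphenyl on an amide-type nitrogen. Because the earlier swap at this position gave a 2.2-fold lower number from compound 1 to compound 2 (0.35 log units; beyond the scatter), a step of comparable, modest size is expected here, though its direction cannot be read from one step alone. The step from compound 2 to compound 3 is therefore expected to be a 1.4-fold lower number from compound 2 to compound 3 (0.13 log units; within the scatter). The value estimated for compound 3 is 90000 nM, with a range running from 30000 nM to 270000 nM.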

Compound 3, half-maximal inhibitory concentration: 156000 nM
Compound 3: the middle estimate sits 1.7-fold (0.24 log units) below what was measured; measured number inside the range.
By their numbers in this assay, from the lowest: compounds 2, 3 and 1 (each within the scatter of the next, the first and the last beyond it).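

In this assay, the change on the amide-type nitrogen gives a 1.3-fold higher number from compound 2 to compound 3 (0.11 log units; within the scatter), and the wider change from 2,3-dimethylphenyl to 4-nitrophenyl gives a 1.7-fold lower number from compound 1 to compound 3 (0.24 log units; within the scatter). So a ring carrying a nitro group, with its added nitrogen and two oxygens, stays within the scatter of both earlier compounds, even though those two differ from each other by more than the scatter. No measurement available here explains this outcome.

As far as these compounds go, all three groups at this position are substituted six-membered aromatic rings of carbon, so it remains open whether a phenyl ring bearing an amine or a carboxylic acid, or a longer alkyl chain in place of the ring, would shift the number beyond the scatter. A 2-nitrophenyl would show whether the nitro group behaves differently at the ring position held by the methoxy group in compound 2.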